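Working notes: from compound 3 to compound 4

The source may hold more compounds than are shown below. What is called first, only, known or untested is meant among the compounds shown, and "the series" means these compounds.

Values in a functional assay on A549 cells (Homo sapiens) for antiproliferative activity, read by MTT assay, with a stated time of 48 h (a higher number here means a weaker inhibitor, a lower number a stronger inhibitor), as measured so far
- compound 1 `Oc1ccc2ccccc2c1C(Nc1nc2ccccc2s1)c1cn(-c2ccccc2)nc1-c1ccccc1` gives 36200 nM
- compound 2 `Cc1cccc(-c2nn(-c3ccccc3)cc2C(Nc2nc3ccccc3s2)c2c(O)ccc3ccccc23)c1` gives 18500 nM
- compound 3 `Oc1ccc2ccccc2c1C(Nc1nc2ccccc2s1)c1cn(-c2ccccc2)nc1-c1cccc(Cl)c1` gives 20400 nM

Compound 3 (20400 nM) lies within the scatter of both other compounds, so no order can be drawn. The next compound is compound 4 `Cc1ccc(-c2nn(-c3ccccc3)cc2C(Nc2nc3ccccc3s2)c2c(O)ccc3ccccc23)cc1`, with 4-methylphenyl in place of 3-chlorophenyl on an aromatic carbon. For the measured compounds named here, three measured steps bear on this: (a 2.0-fold lower number from compound 1 to compound 2 (0.29 log units; within the scatter)), (a 1.8-fold lower number from compound 1 to compound 3 (0.25 log units; within the scatter)) and (a 1.1-fold higher number from compound 2 to compound 3 (0.04 log units; within the scatter)). Going by the values given here, all lie within the scatter, though no measured compound carries 4-methylphenyl. In this assay the expected step is small and not beyond the scatter (a 1.1-fold higher number from compound 3 to compound 4 (0.03 log units; within the scatter)). For compound 4 the estimated value is 22000 nM with an expected range of 11000 nM to 42000 nM in this assay.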

Compound 4, half-maximal inhibitory concentration: 57400 nM
Beside the measured number, compound 4's estimate is 2.6-fold (0.42 log units) below it; the measured number lies above the stated range.
By their numbers in this assay, from the lowest: compounds 2, 3, 1 and 4 (each within the scatter of the next, the first and the last beyond it).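

In this assay, for the compounds shown here, this position now gives steps beyond the scatter, which no earlier pair did (a 2.8-fold higher number from compound 3 to compound 4 (0.45 log units; beyond the scatter); a 3.1-fold higher number from compound 2 to compound 4 (0.49 log units; beyond the scatter)). The second step only exchanges 3-methylphenyl for 4-methylphenyl, so among these compounds the place of the methyl on the phenyl counts, while the step to the plain phenyl stays within the scatter (a 1.6-fold higher number from compound 1 to compound 4 (0.20 log units; within the scatter)). Nothing on hand explains this difference. Still open, as far as these compounds go, is whether it holds for other groups on this phenyl, such as 4-chlorophenyl or a phenyl carrying an amine or a carboxylic acid.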